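Ester side chain variation in a dihydropyridine calcium channel series

The source may hold more compounds than are shown below. What is called first, only, known or untested is meant among the compounds shown, and "the series" means these compounds.

Measured so far:
compound 1, `CCOC(=O)C1=C(C)NC(COC)=C(C(=O)OC)C1c1cccc([N+](=O)[O-])c1` — 14 nM
compound 2, `COCC1=C(C(=O)OC)C(c2cccc([N+](=O)[O-])c2)C(C(=O)OC)=C(C)N1` — 115 nM
compound 3, `C=C(C)CCOC(=O)C1=C(C)NC(C)=C(C(=O)OC)C1c1cccc([N+](=O)[O-])c1` — 23 nM

In a functional assay on HEK293 cells for antagonist activity at Voltage-dependent L-type calcium channel subunit alpha-1C (Oryctolagus cuniculus), read by FLIPR (a higher number here means a weaker inhibitor, a lower number a stronger inhibitor), compound 3 stands second highest of the three numbers. Its nearest neighbour is compound 1, whose number is lower by an amount within the scatter of repeated measurements; the furthest is compound 2, whose number is higher by an amount beyond the scatter.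

The next compound, compound 4, `COC(=O)C1=C(C)NC(C)=C(C(=O)OCc2ccc(OC)c(OC)c2)C1c1cccc([N+](=O)[O-])c1`, is not yet measured. It differs from compound 3 only in the ester side chain: 3,4-dimethoxyphenyl in place of 2-methylprop-2-en-1-yl on a saturated chain carbon bound to an oxygen next to a carbonyl group

Going by the values given here, only one measured step touches the same place. It is an 8.2-fold higher number from compound 1 to compound 2 (0.91 log units; beyond the scatter), and it shows that a change on the saturated chain carbon bound to an oxygen next to a carbonyl group can shift the number well beyond the scatter. That step, however, concerns a small change in the opposite sense of size, so it gives no direct reading for the entry of 3,4-dimethoxyphenyl. On this basis the author expects the number for compound 4 in this assay to stay close to that of compound 3, with a step of about a 1.3-fold lower number from compound 3 to compound 4 (0.11 log units; within the scatter), probably within the scatter.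

The estimate for compound 4 in this assay is therefore 18 nM, with a range from 4 nM to 80 nM.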

Compound 4, half-maximal inhibitory concentration: 112 nM
Compound 4: the middle estimate sits 6.2-fold (0.79 log units) below what was measured; measured number outside the range, above it.
By their numbers in this assay, from the lowest: compounds 1 and 3 (each within the scatter of the next); then compounds 4 and 2 (each within the scatter of the next).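

In this assay, placing 3,4-dimethoxyphenyl in place of 2-methylprop-2-en-1-yl on the saturated chain carbon bound to an oxygen next to a carbonyl group gives a 4.9-fold higher number from compound 3 to compound 4 (0.69 log units; beyond the scatter). The earlier compounds had shown only the small change of hydrogen in place of methyl at this place, an 8.2-fold higher number from compound 1 to compound 2 (0.91 log units; beyond the scatter), so it is now clear that a much larger entering group carrying an aromatic ring also moves the number upward beyond the scatter, and that in these two pairs both the smaller and the larger side chain give a weaker inhibitor than the compound it is compared with. Nothing available explains this rise.

The compounds shown leave open whether the rise goes with the aromatic ring itself or with its two methoxy groups, a question that a plain benzyl group on the same carbon would separate. Going by these compounds, how a longer saturated chain or a chain ending in an amine would read at this place also remains open.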